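Nitrogen substituent series: cyclopropyl to isobutyl

The compounds below may be only part of what the source reports. "The series", "measured", "known", "first", "only" and "open" are said of these compounds alone.

Measured in an ADME assay on a cell-free system (plasma, Rattus norvegicus) for metabolic stability, read by LC-MS, with a stated time of 1 h, at 37 degrees C, tested at 100 uM; a lower number here means that less of the compound is left, a higher number that more of the compound is left:
- compound 1 `O=C(O)c1cc(-c2cccc(COc3ccc4c(=O)n(C5CCC5)sc4c3)c2)ccc1Cl`: 91%
- compound 2 `O=C(O)c1cc(-c2cccc(COc3ccc4c(=O)n(C5CC5)sc4c3)c2)ccc1Cl`: 100%

Compound 2 stands at 100%, within the scatter of compound 1. The next structure is compound 3 `CC(C)Cn1sc2cc(OCc3cccc(-c4ccc(Cl)c(C(=O)O)c4)c3)ccc2c1=O`, with isobutyl in place of cyclopropyl on an aromatic nitrogen, next to the ring sulfur: isobutyl in place of cyclopropyl on an aromatic nitrogen.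

Within the data shown here, one measured step bears on this change at the same place: a number 9 percentage points higher from compound 1 to compound 2 (within the scatter). Among the measured compounds shown here, that step exchanged one carbon ring for another, so the data hold no measured step from a ring to an open chain, and the evidence is thin. For the measured compounds named here, with only that step to go on, no change beyond the scatter is expected in this assay. The expected step is a number 6 percentage points lower from compound 2 to compound 3 (within the scatter). For compound 3 the estimated value is 94%, with an expected range of 82% to 100%.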

Compound 3, percent of the compound remaining: 95%
Beside the measured number, compound 3's estimate is 1 percentage points below it; the range from low to high includes it.
By their numbers in this assay, from the lowest: compounds 1, 3 and 2 (each within the scatter of the next).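

On the aromatic nitrogen, next to the ring sulfur, the move from a ring to an open chain gives a number 5 percentage points lower from compound 2 to compound 3 (within the scatter) in this assay and, set against the cyclobutyl compound, a number 4 percentage points higher from compound 1 to compound 3 (within the scatter) as the second step. The three nitrogen substituents, cyclopropyl, cyclobutyl and isobutyl, therefore cannot be told apart by this read-out, whether a ring is present or not. No measurement here offers an explanation for this result.

On these data alone, a nitrogen substituent carrying an amine, a hydroxyl or an ester, or a longer chain such as hexyl, remains open at this place. The same holds for an ester in place of the carboxylic acid shared by all three compounds, which would test a different part of the core in this assay on its own terms.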